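The source may hold more compounds than are shown below. What is called first, only, known or untested is meant among the compounds shown, and "the series" means these compounds.

Among the compounds with values here, compound 1 `Cc1cccc(Cc2nc3cc(O[C@H]4CC[C@@H](C(=O)O)CC4)ccc3n2C)c1` gives 30 nM in an assay on isolated protein for inhibition of Long-chain-fatty-acid--CoA ligase 1 (Mus musculus), read by mass spectrometry, with a stated time of 90 min, in the presence of a further agent that is not named here (on this read-out higher numbers stand for weaker inhibition and lower numbers for stronger inhibition), the lowest of the three numbers measured so far. Compound 2 `Cc1cccc(Cc2cc3cc(O[C@H]4CC[C@@H](C(=O)O)CC4)ccc3n2C)c1` gives 400 nM in this assay, and compound 3 `Cc1cccc(Cc2c(C#N)c3cc(O[C@H]4CC[C@@H](C(=O)O)CC4)ccc3n2C)c1` gives 600 nM. Within the data shown here, the only single-point comparison among them is a 1.5-fold higher number from compound 2 to compound 3 (0.18 log units; within the scatter), a change on a different part of the shared core. Compound 4 `Cc1ccc(Cc2nc3cc(O[C@H]4CC[C@@H](C(=O)O)CC4)ccc3n2C)cc1` differs from compound 1 by 4-methylphenyl in place of 3-methylphenyl on a saturated chain carbon bound to an aromatic carbon. Among the measured compounds shown here, no measured pair alters this part of the molecule, so the step from compound 2 to compound 3 does not bear on it, and there is no ground for expecting a large shift in either direction. With nothing to anchor the change, compound 4 is estimated at 60 nM, within 15 nM to 250 nM. The expected step of a 2.0-fold higher number from compound 1 to compound 4 (0.30 log units; within the scatter) is therefore modest.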

Compound 4, half-maximal inhibitory concentration: 80 nM
Beside the measured number, compound 4's estimate is 1.3-fold (0.12 log units) below it; the range from low to high includes it.
By their numbers in this assay, from the lowest: compound 1; then compound 4; then compounds 2 and 3 (each within the scatter of the next).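

Swapping 3-methylphenyl for 4-methylphenyl, with the same atoms joined differently, gives a 2.7-fold higher number from compound 1 to compound 4 (0.43 log units; beyond the scatter). Compounds 1, 2 and 3 all carry 3-methylphenyl, so only now is it visible that the place of the methyl on this ring alone can shift the number, and that 3-methylphenyl is the better of the two here. No evidence is available to explain this step.

Still open, going by these compounds, is how plain phenyl, or a methoxy group in place of the methyl, would compare. Whether this swap has a similar effect on the cores of compound 2 and compound 3 is also unknown.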